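This account rests on a few compounds, and the source may have more. Where it says the series, first, only, none or still open, it means among the compounds named here.

Measured compounds:
Compound 1, `Cc1ccc2[nH]c(C(=O)O)c(CCC(=O)O)c2c1`. In an assay on isolated protein for inhibition of kynurenine--oxoglutarate transaminase 1 (Homo sapiens), read by HPLC, with a stated time of 20 min (on this read-out lower numbers stand for stronger inhibition and higher numbers for weaker inhibition), compound 1 gives only a limit, > 1000000 nM.
Compound 2, `CCOC(=O)/C(CCCC(=O)O)=N\Nc1ccc([N+](=O)[O-])cc1`. In this assay compound 2 gives 179000 nM.
Compound 3, `CCOC(=O)/C(CCCC(=O)O)=N\Nc1ccc(I)cc1`. In this assay compound 3 gives 34000 nM.

Compound 2 holds the highest of the two numbers; the nearest is compound 3, reached by a 5.3-fold lower number from compound 2 to compound 3 (0.72 log units; beyond the scatter). Compound 4, `CCOC(=O)/C(CCCC(=O)O)=N\Nc1ccc(Cl)cc1`, is not yet measured; it differs from compound 2 as chloro in place of nitro on an aromatic carbon. Within the data shown here, the one measured step that bears on this change is the iodo in place of nitro step, a 5.3-fold lower number from compound 2 to compound 3 (0.72 log units; beyond the scatter), modest but beyond the scatter. With chloro entering where iodo entered before, a lower number in the same direction is expected in this assay, though a somewhat smaller step than with iodo seems plausible. Compound 4 is estimated at 55000 nM, between 15000 nM and 200000 nM. The step expected from this estimate is a 3.3-fold lower number from compound 2 to compound 4 (0.51 log units; beyond the scatter).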

Compound 4, half-maximal inhibitory concentration: 20000 nM
Estimate against measurement, compound 4: 2.8-fold (0.44 log units) above, and the stated range covers the measured number.
By their numbers in this assay, from the lowest: compounds 4 and 3 (each within the scatter of the next); then compound 2. At a limit, above all of these: compound 1.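

In this assay chloro in place of nitro, on the aromatic carbon para to a large group, gives a 9.0-fold lower number from compound 2 to compound 4 (0.95 log units; beyond the scatter) and so the lower number seen with iodo is not tied to iodo alone. Chloro and iodo differ by only a 1.7-fold lower number from compound 3 to compound 4 (0.23 log units; within the scatter) and cannot be ranked at this position. Nothing measured here speaks to the reason for these steps.

Going by these compounds, whether an amine or a methoxy group at this position would fall with the two halogens or with nitro stays open. So does the effect of a longer chain in place of the chain carrying the carboxylic acid.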